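Debenzylation on two differently joined cores of the series

The source may hold more compounds than are shown below. What is called first, only, known or untested is meant among the compounds shown, and "the series" means these compounds.

Measured compounds:
Compound 1 `CCOC(=O)c1cc(-c2cc(OC)c(OC)c(OC)c2)c(-c2ccc(OC)c(OCc3ccccc3)c2)s1`: in a functional assay on HT-1080 cells (Homo sapiens) for antiproliferative activity, read by MTT assay, with a stated time of 72 h (on this read-out lower numbers stand for stronger inhibition and higher numbers for weaker inhibition), compound 1 gives only a limit, > 100000 nM.
Compound 2 `CCOC(=O)c1cc(-c2cc(OC)c(OC)c(OC)c2)c(-c2ccc(OC)c(O)c2)s1`: in this assay compound 2 gives 3220 nM.
Compound 3 `CCOC(=O)c1cc(-c2ccc(OC)c(OCc3ccccc3)c2)c(-c2cc(OC)c(OC)c(OC)c2)s1`: in this assay compound 3 gives only a limit, > 100000 nM.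

Compound 1 and compound 3 have the same atoms joined differently; the difference between the two cores is not broken down here. Among the compounds with values here, the one measured step in the set is an at least 31-fold lower number from compound 1 to compound 2 (1.49 log units; beyond the scatter), brought about by hydrogen in place of benzyl on an oxygen on an aromatic ring. Its size is only a lower bound, because the starting point is the assay limit (the limit of > 100000 nM in this assay, at which 2 of the 3 values shown sit).

Compound 4 `CCOC(=O)c1cc(-c2ccc(OC)c(O)c2)c(-c2cc(OC)c(OC)c(OC)c2)s1` is not yet measured. It differs from compound 3 by hydrogen in place of benzyl on an oxygen on an aromatic ring, and as the description of the place is the same word for word as for the change from compound 1 to compound 2, this is the same change, made on the other core.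

For compound 4 in this assay a step of an at least 10-fold lower number from compound 3 to compound 4 (1.00 log units; beyond the scatter) is expected, resting on the measured at least 31-fold lower number from compound 1 to compound 2 (1.49 log units; beyond the scatter); since the step from compound 1 to compound 2 is itself bounded by the limit (the limit of > 100000 nM in this assay, at which 2 of the 3 values shown sit), and the two cores are not compared elsewhere, the expectation is loose. The estimate for compound 4 in this assay is 10000 nM, expected to fall between 2000 nM and 100000 nM.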

Compound 4, half-maximal inhibitory concentration: 82600 nM
For compound 4 the middle estimate is 8.3-fold (0.92 log units) below the measured one; low and high end bracket the measured number.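

On the second core, benzyloxy to hydroxy gives an at least 1.2-fold lower number from compound 3 to compound 4 (0.08 log units; that floor lies within the scatter) in this assay, so the floor of this step does not by itself establish a gain on that core. Set beside the step on the first core, this shows that the same change can be read on both cores, yet it does not show that its size carries over from one core to the other, nor that it fails to: the same change on two cores in this assay, an at least 31-fold lower number (1.49 log units; beyond the scatter) from compound 1 to compound 2 and an at least 1.2-fold lower number (0.08 log units; that floor lies within the scatter) from compound 3 to compound 4; the limit leaves it open whether they differ. Neither step has a true size, and the comparison stays bounded on both sides of the series for that reason: the limit of > 100000 nM in this assay, at which 2 of the 4 values shown sit.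

Only hydrogen and benzyl are shown on this oxygen, so it remains open how a methyl, a longer chain or a chain ending in an amine would read there on either core. The ethyl ester is also the same throughout, which leaves open whether a carboxylic acid or an amide in its place would shift the numbers in this assay, and whether any such change would act alike on the two cores.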